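This account rests on a few compounds, and the source may have more. Where it says the series, first, only, none or still open, it means among the compounds named here.

Measured compounds in a functional assay on MGC-803 cells (Homo sapiens) for antiproliferative activity, read by CCK-8 assay, with a stated time of 72 h, tested at 2 uM; on this read-out lower numbers stand for a weaker effect and higher numbers for a stronger effect at the one concentration tested:
- compound 1, `COc1ccc(N2CCN(C(=S)SCc3ccc(C(=O)Nc4ccccc4N)cc3)CC2)cc1`: compound 1 gives 25.3%
- compound 2, `Nc1ccccc1NC(=O)c1ccc(CSC(=S)N2CCN(Cc3cccnc3)CC2)cc1`: compound 2 gives 37.7%

Within the data shown here, compound 2 stands highest of the two numbers; the nearest is compound 1, and the one measured step, a number 12.4 percentage points higher from compound 1 to compound 2 (beyond the scatter), lies beyond the scatter.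

Compound 3, `Nc1ccccc1NC(=O)c1ccc(CSC(=S)N2CCN(c3cnccn3)CC2)cc1`, is not yet measured. Its change from compound 2 is pyrazin-2-yl in place of (pyridin-3-yl)methyl on an amine nitrogen in a ring. Among the measured compounds shown here, the only step that bears on this is the one from compound 1 to compound 2, which swapped an aryl group on the ring nitrogen for (pyridin-3-yl)methyl and raised the read-out by a modest amount. Compound 3 goes the other way in that it again places an aromatic ring directly on the ring nitrogen, though the entering ring is pyrazin-2-yl rather than 4-methoxyphenyl. For the measured compounds named here, the expectation is therefore a step of a number 8.7 percentage points lower from compound 2 to compound 3 (within the scatter) in this assay, downward, roughly as large as the step from compound 1 to compound 2 but with no second example to fix its size. Compound 3 is expected to give 29%, with a range from 15% to 43%.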

Compound 3, a percentage reported as inhibition, at one concentration (the size of the read-out at that concentration, not a potency): 27.1%
Beside the measured number, compound 3's estimate is 1.9 percentage points above it; the range from low to high includes it.
By their numbers in this assay, from the lowest: compounds 1 and 3 (each within the scatter of the next); then compound 2.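

In this assay, pyrazin-2-yl in place of (pyridin-3-yl)methyl on the amine nitrogen in the ring gives a number 10.6 percentage points lower from compound 2 to compound 3 (beyond the scatter), so a nitrogen-containing aromatic ring at this position does not by itself preserve the read-out of compound 2. Among these compounds, exchanging one directly attached aromatic ring for another, with pyrazin-2-yl in place of 4-methoxyphenyl, gives a number 1.8 percentage points higher from compound 1 to compound 3 (within the scatter), which places two quite different directly attached rings level in this assay and leaves compound 2, the only compound here with a methyl link to its ring, apart from both. No supporting measurement bears on why the read-out shifts at this position.

Still open, from the compounds shown here alone, is whether the methyl link or the identity of the ring accounts for the step, as compound 2 and compound 3 differ in both. A pyrazin-2-ylmethyl or plain benzyl group on this nitrogen would help separate the two, while a longer chain ending in pyridin-3-yl or an open-chain amine would test how far the read-out depends on the length of the link and on the presence of an aromatic ring.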